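Working notes: a new aryl group on the shared core

The source may hold more compounds than are shown below. What is called first, only, known or untested is meant among the compounds shown, and "the series" means these compounds.

Of the compounds shown here, two have numbers so far, compound 1 (`COc1ccc(C2=NOC(COc3ccc(-c4nnnn4-c4cc(OC)c(OC)c(OC)c4)cc3N)C2)cc1OC`) and compound 2 (`COc1ccc(F)c(C2=NOC(COc3ccc(-c4nnnn4-c4cc(OC)c(OC)c(OC)c4)cc3N)C2)c1`). Among the compounds with values here, in a functional assay on A549 cells (Homo sapiens) for cytotoxicity, read by MTT assay, with a stated time of 48 h (on this read-out higher numbers stand for weaker inhibition and lower numbers for stronger inhibition), compound 1 gives 2520 nM and compound 2 gives 1510 nM, so compound 2 stands level with its only measured neighbour. Compound 3 (`COc1cc(-n2nnnc2-c2ccc(OCC3CC(c4ccc(OC)c(OC)c4OC)=NO3)c(N)c2)cc(OC)c1OC`) has no number yet. Its difference from compound 2 is 2,3,4-trimethoxyphenyl in place of 2-fluoro-5-methoxyphenyl on a carbon with a double bond to nitrogen. Within the data shown here, one measured step bears on this place: a 1.7-fold lower number from compound 1 to compound 2 (0.22 log units; within the scatter), which lies within the scatter. That single small step is thin evidence, but it gives no sign that this position moves the number far. The entering group carries methoxy groups and no fluorine, like the 3,4-dimethoxyphenyl of compound 1 (2520 nM), so a value near that one seems reasonable. The expected change is a 1.5-fold higher number from compound 2 to compound 3 (0.16 log units; within the scatter), and no step beyond the scatter is expected in this assay. For compound 3 the estimated value is 2200 nM, with an expected range from 800 nM to 6000 nM in this read-out.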

Compound 3, half-maximal inhibitory concentration: 2030 nM
Compound 3: middle estimate off by 1.1-fold (0.03 log units), on the high side, within the range that was stated.
By their numbers in this assay, from the lowest: compounds 2, 3 and 1 (each within the scatter of the next).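

In this assay, replacing 2-fluoro-5-methoxyphenyl with 2,3,4-trimethoxyphenyl gives a 1.3-fold higher number from compound 2 to compound 3 (0.13 log units; within the scatter), and methoxy in place of hydrogen on an aromatic carbon of the ring at the same place gives a 1.2-fold lower number from compound 1 to compound 3 (0.09 log units; within the scatter). Where the earlier pair offered one small step, three aryl groups now stand on this carbon with a double bond to nitrogen without any step beyond the scatter, so neither the swap of fluorine for methoxy substitution nor the extra methoxy separates the numbers in this set. No measurement on hand offers an explanation for how closely these numbers lie.

From the compounds shown here alone, all three groups are phenyl rings carrying methoxy groups, so it remains open whether the number would hold with a carboxylic acid or a dimethylamino group on that ring, or with butoxy in place of methoxy. The rest of the shared core is the same in all three compounds, so these steps say nothing about how changes elsewhere on it would read out.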